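Swapping methyl for cyano on a cytotoxic urea series

The source may report more compounds than this note shows. Statements on the series, on what has been measured and on what is new or still open speak of the compounds shown alone.

Compound 2 `COc1cc(CN(C(=O)Nc2ccc(C)cc2)n2cnnc2)cc(OC)c1OC` was tested in a functional assay on MCF7 cells (Homo sapiens) for cytotoxicity, read by MTT assay, with a stated time of 48 h; on this read-out higher numbers stand for weaker inhibition and lower numbers for stronger inhibition. For compound 2 the result is only a limit of the assay, > 50000 nM. Compound 1 `CCc1ccc(NC(=O)N(Cc2cc(OC)c(OC)c(OC)c2)n2cnnc2)cc1` gives 24800 nM in this assay, and the step of an at least 2.0-fold higher number from compound 1 to compound 2 (0.30 log units; that floor lies within the scatter) is hydrogen in place of methyl on a saturated chain carbon bound to an aromatic carbon. Compound 3 `COc1cc(CN(C(=O)Nc2ccc(C#N)cc2)n2cnnc2)cc(OC)c1OC` differs from compound 2 by cyano in place of methyl on an aromatic carbon, para to a large group. For the measured compounds named here, no measured step covers this change; the only guide is that compound 2 sits at the limit of > 50000 nM in this assay, at which 1 of the 2 values shown sits. Compound 3 is expected near 50000 nM, between 15000 nM and 150000 nM, an estimated step of a number no higher from compound 2 to compound 3 (the limit leaves the size open) meaning no clear change.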

Compound 3, half-maximal inhibitory concentration: > 50000 nM
Compound 3: no number, only a limit; the forecaster's own chance of this, stated with the estimate: 60%; the middle value sits exactly at the limit.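

In this assay compound 3 gives only a limit of the assay, as compound 2 does, so the step between these two cannot be read. Cyano in place of ethyl on the ring gives an at least 2.0-fold higher number from compound 1 to compound 3 (0.30 log units; that floor lies within the scatter) and so adds a second group at this position that yields no number, after methyl. Of the three groups shown here, only ethyl gives a measured value: the limit of > 50000 nM in this assay, at which 2 of the 3 values shown sit.

As far as these compounds go, whether a longer chain such as propyl, or an amine, at this position would give a measured value stays open. So does any real difference between methyl and cyano.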